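Working notes: trifluoromethyl step from compound 1

The source may hold more compounds than are shown below. What is called first, only, known or untested is meant among the compounds shown, and "the series" means these compounds.

Measured in a functional assay on HT-29 cells (Homo sapiens) for antiproliferative activity, read by MTT assay, with a stated time of 72 h; on this read-out higher numbers stand for weaker inhibition and lower numbers for stronger inhibition:
- compound 1 `C=CC(=O)Nc1nc(-c2ccccc2)cs1`: 6600 nM
- compound 2 `C=CC(=O)Nc1nc(-c2cccc(Cl)c2)cs1`: 11000 nM

Within the data shown here, compound 1, at 6600 nM, is one of only two measured values and cannot be separated from the other. Compound 3 `C=CC(=O)Nc1nc(-c2ccc(C(F)(F)F)cc2)cs1` has not yet been measured. Its change from compound 1 is trifluoromethyl in place of hydrogen on an aromatic carbon, so trifluoromethyl takes the place of hydrogen on an aromatic carbon, para to a large group. Among the measured compounds shown here, one measured step bears on this, also a single substitution on an aromatic carbon, and it stayed small: a 1.7-fold higher number from compound 1 to compound 2 (0.22 log units; within the scatter). That single case gives no firm direction, so no step beyond the scatter is expected in this assay. The expected step is a 1.3-fold higher number from compound 1 to compound 3 (0.11 log units; within the scatter). For compound 3 the estimated value is 8500 nM, with an expected range of 3500 nM to 22000 nM.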

Compound 3, half-maximal inhibitory concentration: 4000 nM
For compound 3 the middle estimate is 2.1-fold (0.33 log units) above the measured one; the measured number falls inside the stated range.
By their numbers in this assay, from the lowest: compounds 3, 1 and 2 (each within the scatter of the next, the first and the last beyond it).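

A step of a 1.7-fold lower number from compound 1 to compound 3 (0.22 log units; within the scatter) in this assay shows that this place, para to a large group, accepts trifluoromethyl, with its 4 heavy atoms, in place of hydrogen without a step beyond the scatter. With a 1.7-fold higher number from compound 1 to compound 2 (0.22 log units; within the scatter) for chloro, this makes two substitutions on the six-membered aromatic ring of compound 1 that stay within the scatter, and neither gives a firm direction. No measurement at hand bears on why the number stays within the scatter for this change.

Whether an amine or a carboxylic acid at this same place would also stay within the scatter is open. So is whether any group on this aromatic ring can move the number beyond the scatter from compound 1.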